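The source may report more compounds than this note shows. Statements on the series, on what has been measured and on what is new or still open speak of the compounds shown alone.

Working notes on the series. The shared core is carried by compound 1 `CCOC(=O)c1sc(-c2cccc(NC(=O)c3ccc(C(F)(F)F)cc3)c2)nc1Nc1ccc(N2CCN(C)CC2)cc1` and compound 2 `CCOC(=O)c1sc(-c2cccc(NC(=O)[C@H]3CC[C@H](C)CC3)c2)nc1Nc1ccc(N2CCN(C)CC2)cc1`, both with an ethyl ester on the core; in a functional assay on Ramos cells (Homo sapiens) for antiproliferative activity, read by CCK-8 assay, with a stated time of 72 h (a higher number here means a weaker inhibitor, a lower number a stronger inhibitor), compound 1 gives "not determined" (no result reported) and compound 2 gives "not determined" (no result reported). Compound 3 `CN1CCN(c2ccc(Nc3nc(-c4cccc(NC(=O)c5ccc(C(F)(F)F)cc5)c4)sc3C(N)=O)cc2)CC1` carries a primary carboxamide in place of that ester. In this assay, for the measured compounds named here, compound 3 gives 1580 nM, and this is the only number so far; compound 1 and compound 2 contribute no value, so compound 3 stands alone and cannot be ranked against either of them.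

Compound 4 `CN1CCN(c2ccc(Nc3nc(-c4cccc(NC(=O)c5ccccc5F)c4)sc3C(N)=O)cc2)CC1` keeps the core and the primary carboxamide of compound 3 and differs only at the amide on the pendant ring: 2-fluorophenyl in place of 4-(trifluoromethyl)phenyl on a carbonyl carbon. Going by the values given here, no measured step between neighbouring compounds exists, so the size of this change has no precedent here. The expectation is a step from compound 3 to compound 4 of a 1.6-fold higher number from compound 3 to compound 4 (0.20 log units; within the scatter), that is, no change clearly beyond the usual scatter, with a slight lean toward a weaker inhibitor. Compound 4 is therefore estimated to give 2500 nM in this assay, with the likely range from 800 nM to 8000 nM.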

Compound 4, half-maximal inhibitory concentration: 1360 nM
Compound 4: middle estimate off by 1.8-fold (0.26 log units), on the high side; the range from low to high includes it.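

In this assay, for the compounds shown here, the first readable step, 2-fluorophenyl in place of 4-(trifluoromethyl)phenyl on a carbonyl carbon gives a 1.2-fold lower number from compound 3 to compound 4 (0.07 log units; within the scatter), so at this position the two aryl groups cannot be told apart. The exchange replaces a group of 10 heavy atoms with one of 7 and three fluorine atoms with one, while the six-membered aromatic ring of carbon only stays, and across this difference the read-out does not move beyond the scatter. Nothing shown accounts for this result.

Steps to compound 1 and compound 2 cannot be read, as neither has a number, so the ethyl ester and the primary carboxamide on the core remain uncompared, as does any aryl group against a saturated ring on the carbonyl carbon. As far as these compounds go, it also remains open whether a group of another kind on that carbonyl carbon, such as a pyridine ring, a phenyl ring bearing a carboxylic acid or an amine, or a longer alkyl chain, would give a step beyond the scatter.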